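This account rests on a few compounds, and the source may have more. Where it says the series, first, only, none or still open, it means among the compounds named here.

Compound 1, `Cn1nc(C(=O)Nc2ccc(-c3ccccc3)c(C(F)(F)F)c2)c(=O)c2ccccc21` — < 14 uL/min, a limit of the assay rather than a number.
Compound 2, `Cn1cc(C(=O)Nc2ccc(-c3cccnc3)c(C(F)(F)F)c2)c(=O)c2ccccc21` — 18 uL/min.

Two compounds have been run in an ADME assay on microsomes from liver (Rattus norvegicus) for metabolic stability, with a stated time of 30 min (on this read-out higher numbers stand for fast clearance and lower numbers for slow clearance), so far. Compound 1 reaches only a limit in this assay, < 14 uL/min, so no true number is known for it. Among the measured compounds shown here, compound 2 gives 18 uL/min in this assay, and this is the single number among the values shown. For the measured compounds named here, the one further value, that of compound 1, is a limit (the limit of < 14 uL/min in this assay, at which 1 of the 2 values shown sits). Going by the values given here, compound 2 therefore stands alone as the only compound with a measured figure.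

The next compound is compound 3, `Cn1cc(C(=O)Nc2ccc(-c3ccccn3)c(C(F)(F)F)c2)c(=O)c2ccccc21`. It has the same atoms as compound 2, joined differently: pyridin-2-yl in place of pyridin-3-yl on an aromatic carbon. Among the compounds with values here, no step between two measured compounds is available here, so there is nothing to set the size of such a move against. The step from compound 2 to compound 3 in this assay is expected to be no larger than the usual scatter, in no firm direction: no change at the digits printed from compound 2 to compound 3 (within the scatter) is the estimated change. Compound 3 is accordingly expected to give about 18 uL/min, with a range from 9 uL/min to 36 uL/min.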

Compound 3, intrinsic clearance in a liver preparation (reported as CLH), per the amount of preparation that the assay uses in the Rattus norvegicus assay: < 14 uL/min
Compound 3 gave a limit, no number; the forecaster's own chance of this, stated with the estimate: 35%; at least 1.2-fold (0.10 log units) between middle value and limit.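

Pyridin-2-yl in place of pyridin-3-yl, on this aromatic carbon ortho to a trifluoromethyl group, gives the first step that can be read at this position: in the Rattus norvegicus assay there is an at least 1.2-fold lower number from compound 2 to compound 3 (0.10 log units; that floor lies within the scatter), so the change shows no rise in clearance, but it also cannot be told apart from no change at all. In a physicochemical assay for solubility, in phosphate buffer, at pH 7.4 (a lower number here means a less soluble compound, a higher number a more soluble compound), compound 2 gives < 1 ug/mL, which is a limit of the assay and not a number. In the physicochemical assay compound 3 gives < 1 ug/mL, again a limit, so no step can be read in this solubility assay and the swap shows no measurable separation on this read-out.

How far the clearance of compound 3 lies under its limit stays open, and with it the true size of the step, as most of the clearance values shown sit at one floor: the limit of < 14 uL/min in the Rattus norvegicus assay, at which 2 of the 3 values shown sit.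

Also open is whether an amine or a carboxylic acid on the ring at this position would lift a compound off the solubility floor that holds both compounds shown: the limit of < 1 ug/mL in the physicochemical assay, at which 2 of the 2 values shown sit.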